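This account rests on a few compounds, and the source may have more. Where it says the series, first, only, none or still open, it means among the compounds named here.

Working notes, acyl series, a functional assay on ACHN cells (Homo sapiens) for cytotoxicity, read by sulforhodamine B assay, with a stated time of 72 h; on this read-out higher numbers stand for weaker inhibition of growth and lower numbers for stronger inhibition of growth. Compound 1 `CC(=O)N1c2ccccc2CCC1C(=O)Nc1cc(C(F)(F)F)cc(C(F)(F)F)c1` gives only the assay limit > 70000 nM in this assay. Among the measured compounds shown here, compound 2 `CCCC(=O)N1c2ccccc2CCC1C(=O)Nc1cc(C(F)(F)F)cc(C(F)(F)F)c1` gives 13900 nM, and the step of an at least 5.0-fold lower number from compound 1 to compound 2 (0.70 log units; beyond the scatter) is the sole measured single-point change. Compound 3 `CCCCCCCCC(=O)N1c2ccccc2CCC1C(=O)Nc1ccccc1C(F)(F)F` differs from compound 2 in both the acyl chain and the aryl amide; in this assay compound 3 gives 8330 nM, a number within the scatter of the value of compound 2. Compound 4 `CCC(=O)N1c2ccccc2CCC1C(=O)Nc1ccccc1C(F)(F)F` differs from compound 3 by hydrogen in place of hexyl on a saturated chain carbon, two bonds along the chain from a carbonyl carbon. For the measured compounds named here, the one measured step bearing on this, from compound 1 to compound 2, ran in the opposite direction, a longer chain giving a lower number, so for the step from compound 3 to compound 4 a higher number is expected, roughly a 4.8-fold higher number from compound 3 to compound 4 (0.68 log units; beyond the scatter). Compound 4 is therefore estimated at 40000 nM, between 12000 nM and 120000 nM, with a real chance that only a limit is returned.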

Compound 4, concentration for 50% growth inhibition: > 80000 nM
Compound 4 was reported as a limit; the forecaster's own chance of this, stated with the estimate: 30%; at least 2.0-fold (0.30 log units) between middle value and limit.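

Hydrogen in place of hexyl on a saturated chain carbon, two bonds along the chain from a carbonyl carbon, gives an at least 9.6-fold higher number from compound 3 to compound 4 (0.98 log units; beyond the scatter) in this assay. The chain therefore matters on this aryl amide too, in the same direction as the step on the other aryl amide, an at least 5.0-fold lower number from compound 1 to compound 2 (0.70 log units; beyond the scatter). Compound 4 returns only a limit, not a number: the limit of > 80000 nM in this assay, at which 1 of the 4 values shown sits.

From the compounds shown here alone, the true size of this step therefore stays unknown. Also open, going by these compounds, is whether a chain longer than octylcarbonyl, or an amine or carboxylic acid at the chain end, would keep or lose the lower number of compound 3.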